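This account rests on a few compounds, and the source may have more. Where it says the series, first, only, none or still open, it means among the compounds named here.

In a functional assay on CHO cells for antagonist activity at prostaglandin E2 receptor EP1 subtype (Homo sapiens), read by FLIPR and calcium flux (on this read-out higher numbers stand for weaker inhibition and lower numbers for stronger inhibition), compound 2 `Cc1ccc(S(=O)(=O)N(Cc2nnc(Cc3ccc(F)cc3)o2)c2cccc(Cl)c2C)cc1` gives 501 nM. Among the compounds with values here, that is the higher of the two numbers recorded so far: the only other compound, compound 1 `CCOc1ccc(Cc2nnc(CN(c3cccc(Cl)c3Cl)S(=O)(=O)c3ccc(C)cc3)o2)cc1`, gives 31.6 nM in this assay, a clearly lower number, and since these two structures differ in more than one place, no single change can be credited with the gap. Compound 3 `COc1ccc(Nc2nnc(CN(c3cccc(Cl)c3C)S(=O)(=O)c3ccc(C)cc3)o2)cc1` has not yet been measured. It arises from compound 2 by one change: (4-methoxyphenyl)amino in place of 4-fluorobenzyl on an aromatic carbon. Within the data shown here, no measured pair shows this exact change, so the size of the step rests on judgment. Given that compound 1 reaches the lower number of 31.6 nM with a different group at the same position, a step toward a lower number is expected for compound 3, though its extent is uncertain. The expected step is a 2.5-fold lower number from compound 2 to compound 3 (0.40 log units; beyond the scatter). Compound 3 is estimated at 200 nM, with a range from 50 nM to 800 nM.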

Compound 3, inhibition constant: 79.4 nM
Compound 3: the middle estimate sits 2.5-fold (0.40 log units) above what was measured, within the range that was stated.
By their numbers in this assay, from the lowest: compound 1; then compound 3; then compound 2.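

In this assay, putting (4-methoxyphenyl)amino in place of 4-fluorobenzyl gives a 6.3-fold lower number from compound 2 to compound 3 (0.80 log units; beyond the scatter), the first single-change step seen at this aromatic carbon of the five-membered ring. It shows that the number at this position responds to the group placed there, and that a group carrying one hydrogen-bond donor and two hydrogen-bond acceptors can stand where 4-fluorobenzyl, with none of either, stood, without the number rising. Nothing measured here explains why the number fell.

This one step changes both the link to the six-membered ring and the substituent on that ring, so the two contributions cannot be separated. Compounds carrying (4-fluorophenyl)amino or 4-methoxybenzyl at this position would be needed to tell them apart.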